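Swapping an ester for a dimethylamide: expected lipophilicity

The source may report more compounds than this note shows. Statements on the series, on what has been measured and on what is new or still open speak of the compounds shown alone.

Of the compounds shown here, two have been measured in a physicochemical assay for lipophilicity; on this read-out lower numbers stand for lower lipophilicity and higher numbers for higher lipophilicity. Compound 1 `C#CCCOC(=O)/C=C(C)/C=C/CC(C)CCCC(C)(C)OC` gives 5.2, the higher of the two numbers, while compound 2 `COC(C)(C)C(O)CCC(C)C/C=C/C(C)=C/C(=O)OC(C)C` gives 3.86, a gap beyond the usual scatter. The next compound, compound 3 `COC(C)(C)CCCC(C)C/C=C/C(C)=C/C(=O)N(C)C`, is compound 1 with a single change dimethylamino in place of (but-3-yn-1-yl)oxy on a carbonyl carbon: the ester is replaced by a dimethylamide, so that four carbons and a triple bond leave and only two carbons enter. In this assay the step of a number 1.90 log units lower from compound 1 to compound 3 (beyond the scatter) is expected to be a clear fall, beyond the scatter. Compound 3 is estimated at 3.3, within a range from 2.7 to 3.9.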

Compound 3, partition coefficient: 3.74
Compound 3: the middle estimate sits 0.44 log units below what was measured; the range from low to high includes it.
By their numbers in this assay, from the lowest: compounds 3 and 2 (each within the scatter of the next); then compound 1.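

In this assay, dimethylamino in place of (but-3-yn-1-yl)oxy on a carbonyl carbon gives a number 1.46 log units lower from compound 1 to compound 3 (beyond the scatter) and so turns the ester into a dimethylamide. This shows that the read-out responds strongly to a change at this position on the shared core. Nothing measured here explains the size of this step.

The compounds shown leave open how much of the step follows from the swap of ester for amide and how much from the atoms that leave. A butyl ester or a dibutylamide on the same carbonyl carbon could help separate the two.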